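The source may hold more compounds than are shown below. What is called first, only, known or untested is meant among the compounds shown, and "the series" means these compounds.

Compound 1 `C=C1CC[C@H]2C(C)(C)[C@@H](Br)CC[C@]2(C)[C@@H]1Cc1cc(O)c(C=O)cc1O` gives 4000 nM in an ADME assay on MT2 cells (Homo sapiens) for cytotoxicity, read by XTT assay (a higher number here means that more compound is tolerated, a lower number that less compound is tolerated), the lowest of the two numbers at hand. Compound 2 `CC(=O)OC[C@@H]1[C@@]2(C)CC[C@H](Br)C(C)(C)[C@@H]2CC[C@@]1(C)O` gives 40000 nM in this assay, a higher figure beyond the scatter, but no single-step comparison links the two. Compound 3 `C=C1CC[C@H]2C(C)(C)[C@@H](Br)CC[C@]2(C)[C@H]1Cc1cc(O)c(C=O)cc1O` is the target of the step from compound 1: the two compounds have the same atoms and bonds and differ only in configuration as drawn: 1 of 4 stereo elements differ; a stereocentre at a saturated ring carbon is drawn R in compound 1 and S in compound 3. For the measured compounds named here, with no epimer pair measured in this assay, the step from compound 1 to compound 3 is expected to stay within the scatter, a 1.3-fold higher number from compound 1 to compound 3 (0.10 log units; within the scatter), neither direction favoured. Compound 3 is therefore estimated at 5000 nM, within 1500 nM to 15000 nM.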

Compound 3, half-maximal cytotoxic concentration: 2000 nM
For compound 3 the middle estimate is 2.5-fold (0.40 log units) above the measured one, and the stated range covers the measured number.
By their numbers in this assay, from the lowest: compounds 3 and 1 (each within the scatter of the next); then compound 2.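

In this assay, turning this one stereocentre at a saturated ring carbon from R to S gives a 2.0-fold lower number from compound 1 to compound 3 (0.30 log units; within the scatter). For the compounds shown here, this epimer pair is the first direct comparison, and it shows no difference in cytotoxicity beyond the scatter. The pair isolates configuration at this position, with no other structural change involved: the fact that compounds 1 and 3 differ only in the configuration as drawn

Compound 2 remains linked to neither epimer by a single step. On these data alone, whether configuration at this carbon would matter as little with a carboxylic acid or an amine on the shared core remains open.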